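Fluoro for cyano on the enone chain of the series

The compounds below may be only part of what the source reports. "The series", "measured", "known", "first", "only" and "open" are said of these compounds alone.

Compound 1 `COc1ccc(/C=C(\C#N)C(=O)c2cc(OC)c(OC)c(OC)c2)cc1O` is the reference point. In an ADME assay on K562 cells (Homo sapiens) for cytotoxicity, read by MTT assay, with a stated time of 5 days (on this read-out lower numbers stand for stronger inhibition and higher numbers for weaker inhibition), compound 1 gives 4200 nM. Compound 3 `COc1ccc(/C=C(\F)C(=O)c2cc(OC)c(OC)c(OC)c2)cc1O` carries one change against it, (fluoro in place of cyano on a double-bonded chain carbon bound to a carbonyl carbon and a double-bonded chain carbon), and in this assay compound 3 gives 13.7 nM. The step is a 310-fold lower number from compound 1 to compound 3 (2.49 log units; beyond the scatter).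

Compound 2 `COc1ccc(/C=C(\C#N)C(=O)c2cc(OC)c(OC)c(OC)c2)c(F)c1` differs from compound 1 in its core, (2-fluoro-4-methoxyphenyl in place of 3-hydroxy-4-methoxyphenyl on a double-bonded chain carbon bound to a double-bonded chain carbon). For compound 2 in this assay only a limit is reported, > 10000 nM, which is the limit of > 10000 nM in this assay, at which 1 of the 3 values shown sits. The step is an at least 2.3-fold higher number from compound 1 to compound 2 (0.37 log units; beyond the scatter), and since it rests on a limit only its direction and a lower bound on its size are known.

Compound 4 `COc1ccc(/C=C(\F)C(=O)c2cc(OC)c(OC)c(OC)c2)c(F)c1` is not yet measured. Against compound 2 it carries fluoro in place of cyano on a double-bonded chain carbon bound to a carbonyl carbon and a double-bonded chain carbon. The place is worded the same as for the step from compound 1 to compound 3, so this is the same change made on the core of compound 2 instead of the core of compound 1. The change occurs twice among the compounds shown, once measured and once pending. The expected step from compound 2 to compound 4 in this assay is estimated as an at least 160-fold lower number from compound 2 to compound 4 (2.22 log units; beyond the scatter), resting on the step from compound 1 to compound 3, a 310-fold lower number from compound 1 to compound 3 (2.49 log units; beyond the scatter), with wider uncertainty because compound 2 gives only > 10000 nM as a starting point. Compound 4 is therefore expected to give about 60 nM in this assay, estimated to fall between 15 nM and 400 nM.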

Compound 4, half-maximal inhibitory concentration: 1190 nM
For compound 4 the middle estimate is 20-fold (1.30 log units) below the measured one; measured number above the stated range.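

Fluoro in place of cyano on the double-bonded chain carbon lowers the number on the core of compound 2 as well, and in this assay the step is an at least 8.4-fold lower number from compound 2 to compound 4 (0.92 log units; beyond the scatter), so the direction seen on the core of compound 1 carries over to this second core. The size of the step does not carry over in any way that can be stated, and this pair leaves open whether the two steps differ: the same change on two cores in this assay, a 310-fold lower number (2.49 log units; beyond the scatter) from compound 1 to compound 3 and an at least 8.4-fold lower number (0.92 log units; beyond the scatter) from compound 2 to compound 4; the limit leaves it open whether they differ. On these data alone, the starting value of compound 2 is a limit and not a number, so the true size of its step stays unknown: the limit of > 10000 nM in this assay, at which 1 of the 4 values shown sits.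

Among these compounds, the change is seen on only two cores, so these compounds say nothing about whether the same direction would hold on any other core, and the fluoro compounds themselves span a wide range, with compound 3 at 13.7 nM and compound 4 at 1190 nM. As far as these compounds go, only cyano and fluoro appear on this chain carbon, so how a chloro or a methyl group there would read in this assay stays open, as does the effect of an amine on the ring that carries the methoxy group.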